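Difluorobenzyl Replaces Methylbenzyl on a Hydroxamate Scaffold

A few compounds are considered here, and "the series" means these few. Any claim that something is new, unique, unknown or untested is made for them only; others in the source may bear on it.

Compound 1 `CCCN1CCC(c2noc(COc3ccc(/C=C/C(=O)NO)cc3)n2)CC1` gives 69% in an assay on isolated protein for inhibition of protein deacetylase HDAC6 (Homo sapiens), read by fluorescence, with a stated time of 1 h, tested at 100 nM; a higher number here means more inhibition at the concentration tested (going by the name of the read-out), a lower number less inhibition.
Compound 2 `Cc1ccccc1CN1CCC(c2noc(COc3ccc(/C=C/C(=O)NO)cc3)n2)CC1` gives 68%.
Compound 3 `Cc1cccc(CN2CCC(c3noc(COc4ccc(/C=C/C(=O)NO)cc4)n3)CC2)c1` gives 73%.

Compound 3 carries the largest of the three numbers, yet every gap separating it from the others lies within the scatter: a number 4 percentage points higher from compound 1 to compound 3 (within the scatter) and a number 5 percentage points higher from compound 2 to compound 3 (within the scatter). The remaining pair behaves the same way, with a number 1 percentage points lower from compound 1 to compound 2 (within the scatter). Across these three compounds the shared core is untouched and only the group on a saturated chain carbon bound to an amine nitrogen in a ring is exchanged, and none of those exchanges moved the read-out beyond the scatter.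

Compound 4 `O=C(/C=C/c1ccc(OCc2nc(C3CCN(Cc4ccc(F)cc4F)CC3)no2)cc1)NO` continues this series at the same place: 2,4-difluorophenyl in place of 3-methylphenyl on a saturated chain carbon bound to an amine nitrogen in a ring. All three measured steps bear on it, since each swaps the substituent at this position, and each was flat. An exchange of one aromatic ring for another here is therefore expected to give a number 3 percentage points lower from compound 3 to compound 4 (within the scatter), with no change beyond the scatter. Compound 4 is estimated at 70%, in a range from 56% to 82%.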

Compound 4, a percentage reported as inhibition, at one concentration (the size of the read-out at that concentration, not a potency): 74%
Estimate against measurement, compound 4: 4 percentage points below; the range from low to high includes it.
By their numbers in this assay, from the lowest: compounds 2, 1, 3 and 4 (each within the scatter of the next).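

In this assay, 2,4-difluorophenyl at this position gives a result indistinguishable from those of the two methylphenyl groups (with a number 1 percentage points higher from compound 3 to compound 4 (within the scatter) and a number 6 percentage points higher from compound 2 to compound 4 (within the scatter)). The same holds against the ethyl group (with a number 5 percentage points higher from compound 1 to compound 4 (within the scatter)), so the flat picture now reaches a ring carrying fluorine as well as rings carrying methyl. No supporting data bear on the cause of this flat response.

On these data alone, whether a carboxylic acid or an amine on this aromatic ring, or a longer chain in place of ethyl, would move the read-out beyond the scatter remains open. Also open, as far as these compounds go, is whether these compounds would separate at other concentrations, since a reading at one concentration is not a potency.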